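Butyl for Trifluoromethyl: Cytotoxicity Outlook for Compound 4

The source may hold more compounds than are shown below. What is called first, only, known or untested is meant among the compounds shown, and "the series" means these compounds.

Compound 1 `Nc1nc(OCC(F)(F)F)c2ncn(/C=C3/CC3(CO)CO)c2n1` gives, in an ADME assay on Akata cells (Homo sapiens) for cytotoxicity, with a stated time of 7 days (on this read-out higher numbers stand for lower toxicity in this test and lower numbers for higher toxicity in this test), only the limit > 20000 nM. Compound 2 `CCCCCCCCOc1nc(N)nc2c1ncn2/C=C1/CC1(CO)CO` likewise reaches only the limit > 20000 nM in this assay. Compound 3 `Nc1nc(NC2CCCCC2)c2ncn(/C=C3/CC3(CO)CO)c2n1` reaches only the limit > 24000 nM in this assay.

Compound 1 therefore stands on no number at all in this assay, and the two compounds measured beside it stand on limits as well. The unmeasured compound 4 `CCCCCOc1nc(N)nc2c1ncn2/C=C1/CC1(CO)CO` differs from compound 1 by butyl in place of trifluoromethyl on a saturated chain carbon bound to an oxygen on an aromatic ring. The step that bears most directly on it is a step that the two limits leave unreadable from compound 1 to compound 2, which changes the same chain carbon; the two others, a step that the two limits leave unreadable from compound 1 to compound 3 and a step that the two limits leave unreadable from compound 2 to compound 3, concern the aromatic carbon itself. None of the three can be sized, because the limit of > 20000 nM in this assay, at which 2 of the 3 values shown sit, and the limit of > 24000 nM in this assay, at which 1 of the 3 values shown sits, cap every value. What can be said is that neither a heptyl chain nor a cyclohexylamino group brought any value below a limit, so no readable step is expected from compound 1 to compound 4 in this assay; the expected step is a step that the limit leaves unreadable from compound 1 to compound 4. Compound 4 is therefore estimated at 30000 nM, between 15000 nM and 80000 nM, and most likely the assay will again report only a limit.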

Compound 4, half-maximal cytotoxic concentration: > 20000 nM
Compound 4: no number, only a limit; the forecaster's own chance of this, stated with the estimate: 85%; the middle value is on the limit's open side.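

Compound 4 also gives only a limit in this assay, so no step linking it to compound 1, compound 2 or compound 3 can be read, because these values are limits and not numbers: the limit of > 20000 nM in this assay, at which 3 of the 4 values shown sit.

The compounds shown leave open how far beyond their limits the true values lie, and whether they differ from one another at all.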